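Cyano in Place of Bromo on a Sulfonyl Ring

The compounds below may be only part of what the source reports. "The series", "measured", "known", "first", "only" and "open" are said of these compounds alone.

Compound 1 `O=C1/C(=C/c2cccc(F)c2)CN(S(=O)(=O)c2ccc(Br)cc2)C/C1=C\c1cccc(F)c1` and compound 2 `N#Cc1ccc(S(=O)(=O)N2C/C(=C\c3cccc(F)c3)C(=O)/C(=C/c3cccc(F)c3)C2)cc1` share one core; compound 3 `O=C1/C(=C/c2ccc(F)cc2)CN(S(=O)(=O)c2ccc(Br)cc2)C/C1=C\c1ccc(F)cc1` and compound 4 `N#Cc1ccc(S(=O)(=O)N2C/C(=C\c3ccc(F)cc3)C(=O)/C(=C/c3ccc(F)cc3)C2)cc1` share another. In a functional assay on HepG2 cells (Homo sapiens) for cytotoxicity, read by MTT assay, with a stated time of 24 h (a higher number here means a weaker inhibitor, a lower number a stronger inhibitor), compound 1 gives 7700 nM, while compound 2 gives 2600 nM. The difference between them, (cyano in place of bromo on an aromatic carbon), brought a 3.0-fold lower number from compound 1 to compound 2 (0.47 log units; beyond the scatter). Compound 3 gives 8000 nM in this assay, and its value sits within the scatter of compound 1. How the core of compound 3 differs from that of compound 1 is not broken down here.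

Compound 4 differs from compound 3 by cyano in place of bromo on an aromatic carbon, the same change seen between compound 1 and compound 2. Resting on that earlier step, compound 4 is expected to show a 3.0-fold lower number from compound 3 to compound 4 (0.47 log units; beyond the scatter) in this assay. The estimate for compound 4 is 2700 nM, within a range from 1500 nM to 5000 nM.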

Compound 4, half-maximal inhibitory concentration: 9800 nM
Beside the measured number, compound 4's estimate is 3.6-fold (0.56 log units) below it, and the stated range ends below it.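

In this assay, cyano in place of bromo gave a 1.2-fold higher number from compound 3 to compound 4 (0.09 log units; within the scatter) and so left no clear shift on the core of compound 3, unlike the drop in the number seen on the core of compound 1. This does not show why the two cores behave differently, and two pairs cannot say which outcome is more typical of the series. What it does show is that the step measured on one core could not be carried over to the other, so the size of this change depends on the core in these two pairs: the same change on two cores in this assay, a 3.0-fold lower number (0.47 log units; beyond the scatter) from compound 1 to compound 2 and a 1.2-fold higher number (0.09 log units; within the scatter) from compound 3 to compound 4, 3.6-fold (0.56 log units) apart, beyond the scatter of two such steps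

On these data alone, how the change would behave on any further core remains open. So does whether a different group at this place on the sulfonyl ring, such as an amine or a carboxylic acid, would give similar steps on both cores.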